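A few compounds are considered here, and "the series" means these few. Any claim that something is new, unique, unknown or untested is made for them only; others in the source may bear on it.

Three compounds have been measured in an ADME assay on microsomes from liver (Homo sapiens) for metabolic stability, with a stated time of 10 min; on this read-out lower numbers stand for a less stable compound and higher numbers for a more stable compound:

compound 1 `CC(C)S(=O)(=O)NC(=O)c1ccc(Nc2nc(NC3(c4ccc(Cl)cc4)CC3)nc(OCC(F)(F)F)n2)cc1`: 100%
compound 2 `CC(C)(C)NC(=O)NCCS(=O)(=O)NC(=O)c1ccc(Nc2nc(NC3(c4ccc(Cl)cc4)CC3)nc(OCC(F)(F)F)n2)cc1`: 96%
compound 3 `O=C(NS(=O)(=O)CCNC(=O)C1CC1)c1ccc(Nc2nc(NC3(c4ccc(Cl)cc4)CC3)nc(OCC(F)(F)F)n2)cc1`: 90%

All three share the same core and differ only in the group carried by the sulfonyl sulfur. Compound 3 has the lowest of the three numbers, yet its gaps to the other two are small: the step of a number 10 percentage points lower from compound 1 to compound 3 (within the scatter) and the step of a number 6 percentage points lower from compound 2 to compound 3 (within the scatter) both lie within the scatter, so compound 3 cannot be called less stable than compound 1 or compound 2.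

Compound 4 `O=C(NS(=O)(=O)c1ccccc1)c1ccc(Nc2nc(NC3(c4ccc(Cl)cc4)CC3)nc(OCC(F)(F)F)n2)cc1` is the next member of this row. It differs from compound 3 in one place: phenyl in place of 2-((cyclopropylcarbonyl)amino)ethyl on a sulfonyl sulfur. Among the measured compounds shown here, the steps that bear on this change are those that also swap the group on the sulfonyl sulfur, namely a number 4 percentage points lower from compound 1 to compound 2 (within the scatter) and a number 10 percentage points lower from compound 1 to compound 3 (within the scatter), neither of which moved the read-out beyond the scatter. For the measured compounds named here, a phenyl has not been tried at this position before, so the direct evidence is thin, but every exchange at this position so far has left this assay essentially unchanged.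

For compound 4 the expected step is therefore a number 2 percentage points higher from compound 3 to compound 4 (within the scatter), no move beyond the scatter. The estimate for compound 4 in this assay is 92%, with a range from 76% to 100%.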

Compound 4, percent of the compound remaining: 100%
Beside the measured number, compound 4's estimate is 8 percentage points below it, within the range that was stated.
By their numbers in this assay, from the lowest: compounds 3, 2, 1 and 4 (each within the scatter of the next).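

In this assay, the group on the sulfonyl sulfur can now be phenyl, a six-membered aromatic ring of carbon only, and replacing 2-((cyclopropylcarbonyl)amino)ethyl with it gives a number 10 percentage points higher from compound 3 to compound 4 (within the scatter) on this read-out. Comparing phenyl with the other two groups gives a number 4 percentage points higher from compound 2 to compound 4 (within the scatter) for the 2-(((tert-butyl)carbamoyl)amino)ethyl exchange and no change at the digits printed from compound 1 to compound 4 (within the scatter) for the isopropyl exchange. The earlier compounds shown here covered only non-aromatic groups at this position, and now all four groups, with or without an aromatic ring, lie within the scatter of one another, so none of them stands apart in this assay.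

No supporting measurement is available to explain why these exchanges leave the read-out so little changed. Among the compounds shown here, still open is whether a pyridine ring, a phenyl carrying a methoxy group, or a longer chain ending in an amine or a carboxylic acid would also stay within the scatter or would be the first group at this position to move the read-out beyond it.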